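Stereocentre inversion in the bromo analogue: compound 3 to compound 4

The source may hold more compounds than are shown below. What is called first, only, known or untested is meant among the compounds shown, and "the series" means these compounds.

In a functional assay on PC-3 cells (Homo sapiens) for antiproliferative activity, read by MTT assay, with a stated time of 72 h, tested at 5 uM (on this read-out higher numbers stand for more inhibition at the one concentration tested (going by the name of the read-out) and lower numbers for less inhibition), compound 1 `CCOC(=O)/C(C#N)=C(/Nc1ccc([N+](=O)[O-])cc1)N[C@H](C)c1ccccc1` gives 2.9%, compound 2 `CCOC(=O)/C(C#N)=C(/Nc1ccc(C(F)(F)F)cc1)N[C@H](C)c1ccccc1` gives 59.4% and compound 3 `CCOC(=O)/C(C#N)=C(/Nc1ccc(Br)cc1)N[C@@H](C)c1ccccc1` gives 24.7%. Compound 3 thus stands second highest of the three, above compound 1 and below compound 2. Within the data shown here, the only measured step, a number 56.5 percentage points higher from compound 1 to compound 2 (beyond the scatter), concerns the aryl substituent and not the stereocentre. Compound 4 `CCOC(=O)/C(C#N)=C(/Nc1ccc(Br)cc1)N[C@H](C)c1ccccc1` differs from compound 3 as follows: the two compounds have the same atoms and bonds and differ only in configuration as drawn: 1 of 2 stereo elements differ; a stereocentre at a saturated chain carbon is drawn S in compound 3 and R in compound 4. Among the measured compounds shown here, no measured pair shares this kind of change, so nothing sets its size or direction. The expected step from compound 3 to compound 4 is therefore a number 0.3 percentage points higher from compound 3 to compound 4 (within the scatter), not beyond the scatter, with wide uncertainty. Compound 4 is estimated at 25%, within 5% to 55%.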

Compound 4, a percentage reported as inhibition, at one concentration (the size of the read-out at that concentration, not a potency): 1.5%
The estimate for compound 4 lay 23.5 percentage points above the measured number; measured number below the stated range.
By their numbers in this assay, from the lowest: compounds 4 and 1 (each within the scatter of the next); then compound 3; then compound 2.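

In this assay, among these compounds, the stereocentre at the saturated chain carbon proves to matter in its own right, with a number 23.2 percentage points lower from compound 3 to compound 4 (beyond the scatter), a kind of change no earlier pair covered, and the step can be laid on that centre alone: the fact that compounds 3 and 4 differ only in the configuration as drawn. With the centre drawn R throughout, the aryl substituent separates unevenly: there is a number 57.9 percentage points lower from compound 2 to compound 4 (beyond the scatter), yet only a number 1.4 percentage points lower from compound 1 to compound 4 (within the scatter), so bromo and nitro stay unresolved while trifluoromethyl stands clear of bromo.

On these data alone, whether the S centre shifts the trifluoromethyl or nitro compounds likewise stays open. So does the outcome with a methoxy group or a carboxylic acid on the aromatic carbon, or with ethyl in place of the methyl on the stereocentre.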